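The source may report more compounds than this note shows. Statements on the series, on what has been measured and on what is new or still open speak of the compounds shown alone.

Compound 2 `c1ccc2c(c1)CN[C@@H](CN(CCCCNC1CCSCC1)[C@H]1CCCc3cccnc31)C2` gives 54.7 nM in a functional assay on cells for antagonist activity at C-X-C chemokine receptor type 4 (Homo sapiens), read by fluorescence and calcium flux, with stated times of 25 min and 90 s; a lower number here means a stronger inhibitor, a higher number a weaker inhibitor.
Compound 1 `c1ccc2c(c1)CN[C@@H](CN(CCCCNC1CCCCC1)[C@H]1CCCc3cccnc31)C2` gives 75.2 nM.

Compound 2 stands at the lower of the two numbers, yet the step of a 1.4-fold lower number from compound 1 to compound 2 (0.14 log units; within the scatter) is within the scatter, so the two compounds cannot be ranked. Compound 3 `O=S1(=O)CCC(NCCCCN(C[C@H]2Cc3ccccc3CN2)[C@H]2CCCc3cccnc32)CC1` has not been measured; it differs from compound 2 by 1,1-dioxothian-4-yl in place of thian-4-yl on an amine nitrogen. Going by the values given here, the only step that bears on this change is the one at the same amine nitrogen, a 1.4-fold lower number from compound 1 to compound 2 (0.14 log units; within the scatter), which was small. A similarly small step, or none beyond the scatter, is therefore expected in this assay: a 1.1-fold higher number from compound 2 to compound 3 (0.04 log units; within the scatter). Compound 3 is expected to give about 60 nM, between 25 nM and 150 nM.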

Compound 3, half-maximal inhibitory concentration: 45.5 nM
Beside the measured number, compound 3's estimate is 1.3-fold (0.12 log units) above it; the range from low to high includes it.
By their numbers in this assay, from the lowest: compounds 3, 2 and 1 (each within the scatter of the next).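

Putting 1,1-dioxothian-4-yl on the amine nitrogen in place of thian-4-yl gives a 1.2-fold lower number from compound 2 to compound 3 (0.08 log units; within the scatter) in this assay, and in place of cyclohexyl it gives a 1.7-fold lower number from compound 1 to compound 3 (0.22 log units; within the scatter). So this position now holds three different six-membered rings, including one with two added oxygens on the sulfur, and the three compounds cannot be ranked. No measurement here explains this result.

Still open, from the compounds shown here alone, is whether a ring carrying an amine or a carboxylic acid, or an open butyl chain, would also stay within the scatter.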